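Replacing 1,3-thiazol-2-yl in compound 3: working notes

A few compounds are considered here, and "the series" means these few. Any claim that something is new, unique, unknown or untested is made for them only; others in the source may bear on it.

Values in a functional assay on U-937 cells (Homo sapiens) for cytotoxicity, read by MTT assay, with a stated time of 3 days; a lower number here means a stronger inhibitor, a higher number a weaker inhibitor:
- compound 1 `N#Cc1c(O)nc(SCc2nc3ccccc3[nH]2)nc1-c1ccccc1`: 3.28 nM
- compound 2 `CNc1nc(SCc2nc3ccccc3[nH]2)nc(-c2ccccc2)c1C#N`: 19.2 nM
- compound 3 `N#Cc1c(Nc2nccs2)nc(SCc2nc3ccccc3[nH]2)nc1-c1ccccc1`: 3.8 nM

Compound 3 stands at the low end of the numbers, with two steps reaching it: a 1.2-fold higher number from compound 1 to compound 3 (0.06 log units; within the scatter), and a 5.1-fold lower number from compound 2 to compound 3 (0.70 log units; beyond the scatter). Compound 4 `N#Cc1c(NNC(N)=S)nc(SCc2nc3ccccc3[nH]2)nc1-c1ccccc1` carries a group of 4 heavy atoms (1 carbon, 2 nitrogen, 1 sulfur; no ring) in place of a group of 5 heavy atoms (3 carbon, 1 nitrogen, 1 sulfur; one five-membered aromatic ring with 2 hetero atoms), on a nitrogen on an aromatic ring, on a nitrogen on an aromatic ring. For the measured compounds named here, no measured compound has this open chain. The closest guide is the modest exchange of methyl for 1,3-thiazol-2-yl on that nitrogen, and a 5.9-fold higher number from compound 1 to compound 2 (0.77 log units; beyond the scatter) is of similar size. A modest rise in this assay is therefore expected, with a 2.1-fold higher number from compound 3 to compound 4 (0.32 log units; beyond the scatter) as the estimated step, though a step within the scatter remains possible. Compound 4 is estimated at 8 nM, with an expected range from 2.5 nM to 30 nM.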

Compound 4, half-maximal inhibitory concentration: 3 nM
Compound 4: middle estimate off by 2.7-fold (0.43 log units), on the high side, and the stated range covers the measured number.
By their numbers in this assay, from the lowest: compounds 4, 1 and 3 (each within the scatter of the next); then compound 2.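

In this assay the open chain on the nitrogen stands level with the 1,3-thiazol-2-yl ring it replaces (a 1.3-fold lower number from compound 3 to compound 4 (0.10 log units; within the scatter)), so at this position a ring and an open chain need not differ, while the methyl of compound 2 remains the one outlier (a 6.4-fold lower number from compound 2 to compound 4 (0.81 log units; beyond the scatter)). Taken whole, the substituent on the aromatic carbon also stands level with the hydroxy of compound 1 (a 1.1-fold lower number from compound 1 to compound 4 (0.04 log units; within the scatter)). No data here explain these results.

Still open, as far as these compounds go, is whether a plain amine or a carboxylic acid on the aromatic carbon, or a longer chain on the nitrogen, would stay level with compound 4.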